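Removing halogens from the amide aryl group of compound 3

The source may hold more compounds than are shown below. What is called first, only, known or untested is meant among the compounds shown, and "the series" means these compounds.

The three measured compounds share one core. Compound 1 `O=C(Nc1cccc(-n2cc(-c3ccncc3)c(-c3ccc(Cl)c(O)c3)n2)c1)Nc1cccc(C(F)(F)F)c1` carries a urea linkage; in a functional assay on SK-MEL-28 cells (Homo sapiens) for inhibition, read by sulforhodamine B assay, with a stated time of 48 h (a lower number here means a stronger inhibitor of growth, a higher number a weaker inhibitor of growth), compound 1 reports only a limit, > 32500 nM. Compound 2 `COc1cc(-c2nn(-c3cccc(NC(=O)Nc4ccc(Cl)c(Cl)c4)c3)cc2-c2ccncc2)ccc1Cl` is likewise a urea, and in this assay compound 2 gives 7320 nM. Compound 3 `COc1cc(-c2nn(-c3cccc(NC(=O)c4ccc(Cl)c(C(F)(F)F)c4)c3)cc2-c2ccncc2)ccc1Cl` has an amide in place of the urea; in this assay compound 3 again reports only a limit, > 32500 nM. Compound 3 therefore stands at the edge of what can be read, a position it shares with compound 1 (the limit of > 32500 nM in this assay, at which 2 of the 3 values shown sit), and only compound 2 has a true number.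

Within the data shown here, the single measured step, an at least 4.4-fold higher number from compound 2 to compound 3 (0.64 log units; beyond the scatter), concerns the linkage to the carbonyl carbon rather than the substituents on the aryl ring. Compound 4 `COc1cc(-c2nn(-c3cccc(NC(=O)c4ccccc4)c3)cc2-c2ccncc2)ccc1Cl` differs from compound 3 in that ring: phenyl in place of 4-chloro-3-(trifluoromethyl)phenyl on a carbonyl carbon. Among the measured compounds shown here, no measured step alters this ring while keeping the amide, so nothing directly anchors the expectation. Since compound 3 sits at the limit, the step of a number no higher from compound 3 to compound 4 (the limit leaves the size open) is expected to be small or unreadable. In this assay compound 4 is expected near 32500 nM, with a range from 8000 nM to 100000 nM.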

Compound 4, concentration for total growth inhibition: > 100000 nM
Compound 4 gave a limit, no number; the forecaster's own chance of this, stated with the estimate: 70%; middle value at least 3.0-fold (0.48 log units) away from the limit.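

Compound 4 reports only a limit in this assay, as does compound 3, and the amide carrying a plain phenyl on the carbonyl carbon therefore gives no true number, just as the amide carrying 4-chloro-3-(trifluoromethyl)phenyl did not: the limit of > 100000 nM in this assay, at which 1 of the 4 values shown sits.

The limit of compound 3 remains a separate one: the limit of > 32500 nM in this assay, at which 2 of the 4 values shown sit.

The step between these two amides cannot be read, but the comparison with the urea gives an at least 13-fold higher number from compound 2 to compound 4 (1.13 log units; beyond the scatter), leaving compound 2 as the only compound shown with a true number, although compound 1, also a urea, stands at a limit.

On these data alone, it remains open whether a single chlorine, an amine or a carboxylic acid on the phenyl ring of the amide would bring an amide of this series to a true number in this assay or leave it at a limit. Also open, as far as these compounds go, is how a urea with plain phenyl would read, which would separate the effect of the linkage from that of the ring substituents.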